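A few compounds are considered here, and "the series" means these few. Any claim that something is new, unique, unknown or untested is made for them only; others in the source may bear on it.

Compound 1, with the structure `COc1ccccc1-c1ncnn1-c1cc(OC)c(OC)c(OC)c1`, was tested in a functional assay on Jurkat cells (Homo sapiens) for antiproliferative activity, read by MTT assay, with a stated time of 72 h; on this read-out higher numbers stand for weaker inhibition and lower numbers for stronger inhibition. In this assay compound 1 gives only a limit, > 10000 nM, and not a measured number. Compound 2, with the structure `COc1cc(-c2ncnn2-c2ccccc2)cc(OC)c1OC`, likewise gives only a limit in this assay, > 10000 nM. Both results therefore rest at the same edge of what the assay can report, namely (the limit of > 10000 nM in this assay, at which 2 of the 2 values shown sit). Compound 3 has the structure `COc1cc(-n2ncnc2-c2cccc(F)c2)cc(OC)c1OC`. It differs from compound 1 in one place: 3-fluorophenyl in place of 2-methoxyphenyl on an aromatic carbon. Going by the values given here, no step between measured compounds is available, and the two values known here do not separate from each other, so there is no measured basis for a direction. The expected step in this assay is a step that the limit leaves unreadable from compound 1 to compound 3, which is no change beyond the usual scatter. Compound 3 is thus estimated at 15000 nM in this assay, with a range from 3000 nM to 60000 nM, and most likely again only a limit.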

Compound 3, half-maximal inhibitory concentration: > 10000 nM
Compound 3: a limit, no number (the forecaster's own chance of this, stated with the estimate: 75%); the middle value does not contradict the limit.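

In this assay, going by these compounds alone, compound 3 gives only a limit, > 10000 nM, as compound 1 does, so no step from compound 1 to compound 3 can be read: the limit of > 10000 nM in this assay, at which 3 of the 3 values shown sit.

The compounds shown leave open whether swapping these groups on the shared core changes the result at all; none of them yields a measured number.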